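Swapping methoxy for trifluoromethyl on the phenyl ring

This account rests on a few compounds, and the source may have more. Where it says the series, first, only, none or still open, it means among the compounds named here.

Compound 3 `COc1ccc(-c2ccnc(C(=O)Nc3ccc(Oc4ccnc5[nH]ccc45)c(F)c3)c2)cc1` gives the lowest number of the three measured compounds in a functional assay on PC-3 cells (Homo sapiens) for cytotoxicity, read by MTT assay, with a stated time of 72 h (on this read-out higher numbers stand for weaker inhibition and lower numbers for stronger inhibition), at 20 nM. Compound 1 `Cc1ccc(-c2ccnc(C(=O)Nc3ccc(Oc4ccnc5[nH]ccc45)c(F)c3)c2)cc1` gives 3970 nM, and compound 2 `CCc1ccc(-c2ccnc(C(=O)Nc3ccc(Oc4ccnc5[nH]ccc45)c(F)c3)c2)cc1` gives 2960 nM. The steps of a 200-fold lower number from compound 1 to compound 3 (2.30 log units; beyond the scatter) and a 150-fold lower number from compound 2 to compound 3 (2.17 log units; beyond the scatter) are both large, whereas a 1.3-fold lower number from compound 1 to compound 2 (0.13 log units; within the scatter) is not. Compound 4 `O=C(Nc1ccc(Oc2ccnc3[nH]ccc23)c(F)c1)c1cc(-c2ccc(C(F)(F)F)cc2)ccn1` carries the change (trifluoromethyl in place of methoxy on an aromatic carbon). Going by the values given here, no measured step covers this exact swap, but methyl and ethyl, groups that like trifluoromethyl lack the oxygen of methoxy, sat far above compound 3 in this assay. The expected step of a 75-fold higher number from compound 3 to compound 4 (1.88 log units; beyond the scatter) is therefore a large rise, with wide uncertainty. Compound 4 is estimated at 1500 nM, ranging from 200 nM to 8000 nM.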

Compound 4, half-maximal inhibitory concentration: 4350 nM
Estimate against measurement, compound 4: 2.9-fold (0.46 log units) below; the range from low to high includes it.
By their numbers in this assay, from the lowest: compound 3; then compounds 2, 1 and 4 (each within the scatter of the next).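

In this assay, the effect of methoxy on this phenyl ring now stands out against a third kind of group: trifluoromethyl also gives a much higher number (a 220-fold higher number from compound 3 to compound 4 (2.34 log units; beyond the scatter)). Compound 4 sits within the scatter of both alkyl compounds (a 1.5-fold higher number from compound 2 to compound 4 (0.17 log units; within the scatter); a 1.1-fold higher number from compound 1 to compound 4 (0.04 log units; within the scatter)), so methyl, ethyl and trifluoromethyl cannot be told apart here. Nothing shown explains the gap to methoxy.

As far as these compounds go, whether ethoxy, a hydroxyl or an amine in this place would keep the low number of compound 3 stays open.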